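A few compounds are considered here, and "the series" means these few. Any claim that something is new, unique, unknown or untested is made for them only; others in the source may bear on it.

Measured so far:
compound 1 `COc1cc(-c2c(C)nn(-c3nc(-c4ccc(Cl)c(Cl)c4)c(SC(C)C)s3)c2C(=O)O)cc(C(F)(F)F)c1`, 1380 nM
compound 2 `Cc1c(-c2cc(Cl)cc(Cl)c2)c(C(=O)O)nn1-c1nc(-c2cccnc2)c(SC(C)C)s1`, "not active" (no number reported)
compound 3 `Cc1nn(-c2nc(-c3ccc(Cl)c(Cl)c3)c(SC(C)C)s2)c(C(=O)O)c1-c1cccc(C(F)(F)F)c1`, 22000 nM

In a functional assay on BJAB cells (Homo sapiens) for antiproliferative activity, with a stated time of 4 days (a higher number here means that more compound is needed for the effect, a lower number that less compound is needed), compound 1 gives 1380 nM and compound 3 gives 22000 nM; the single-place step a 16-fold higher number from compound 1 to compound 3 (1.20 log units; beyond the scatter). Compound 2 stands apart: in this assay compound 2 is reported as "not active" (no number reported), so no number fixes where it sits. Compound 4 `Cc1c(-c2cc(Cl)cc(Cl)c2)c(C(=O)O)nn1-c1nc(-c2cc(Cl)cc(Cl)c2)c(SC(C)C)s1` carries 3,5-dichlorophenyl in place of pyridin-3-yl on an aromatic carbon. Within the data shown here, no measured step covers this exchange; the only measured step, methoxy against hydrogen, concerns a different ring and gives no direction for this assay here. Compound 1 and compound 3, the two with numbers, carry a dichlorophenyl where compound 2 carries pyridin-3-yl. Compound 4 is therefore expected to return a number, estimated at 5000 nM, within 1000 nM to 30000 nM.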

Compound 4, half-maximal effective concentration: 2000 nM
Estimate against measurement, compound 4: 2.5-fold (0.40 log units) above; measured number inside the range.
By their numbers in this assay, from the lowest: compounds 1 and 4 (each within the scatter of the next); then compound 3.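

Compound 2 carries no number in this assay, so the step from it to compound 4 cannot be read. The compounds shown leave open how far exchanging pyridin-3-yl for 3,5-dichlorophenyl moves the number. No measurement here bears on the reason for this result.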